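The compounds below may be only part of what the source reports. "The series", "measured", "known", "first", "only" and "open" are said of these compounds alone.

Compound 1 `C#CCOc1ccc2cc(C(=O)OC)c(=O)oc2c1` is the starting point. In an assay on cells for inhibition of Amine oxidase [flavin-containing] A (Homo sapiens), read by Amplex Red, with stated times of 30 min and 45 min (a lower number here means a stronger inhibitor, a higher number a weaker inhibitor), compound 1 gives 1570 nM. Compound 2 `C#CCCOc1ccc2cc(C(=O)OC)c(=O)oc2c1` differs from it in one place: propargyl in place of ethynyl on a saturated chain carbon bound to an oxygen on an aromatic ring In this assay compound 2 gives 818 nM, and the step is a 1.9-fold lower number from compound 1 to compound 2 (0.28 log units; within the scatter). Compound 3 `C#CCCCOc1ccc2cc(NC(C)=O)c(=O)oc2c1` is built on a different core; the difference between the core of compound 1 and the core of compound 3 is not broken down here. In this assay compound 3 gives 930 nM. Compound 4 `C#CCCCCOc1ccc2cc(NC(C)=O)c(=O)oc2c1` has not yet been measured and differs from compound 3 in one place: propargyl in place of ethynyl on a saturated chain carbon, three bonds along the chain from an oxygen on an aromatic ring In compound 2 the change sits on a saturated chain carbon bound to an oxygen on an aromatic ring, whereas in compound 4 it sits on a saturated chain carbon three bonds along the chain from an oxygen on an aromatic ring, so this is the same kind of change, not the same change. Because the earlier step was a 1.9-fold lower number from compound 1 to compound 2 (0.28 log units; within the scatter) and stayed within the scatter, the step from compound 3 to compound 4 is expected to be a 1.3-fold lower number from compound 3 to compound 4 (0.12 log units; within the scatter). In this assay compound 4 is estimated at 700 nM, expected to fall between 300 nM and 1600 nM.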

Compound 4, half-maximal inhibitory concentration: 66.8 nM
Compound 4: the middle estimate sits 10-fold (1.02 log units) above what was measured, and the stated range ends above it.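

In this assay the swap of ethynyl for propargyl gives a 14-fold lower number from compound 3 to compound 4 (1.14 log units; beyond the scatter) and so counts as a large step. Set beside the earlier step on the other core, the same kind of change does not keep its size: the same change on two cores in this assay, a 1.9-fold lower number (0.28 log units; within the scatter) from compound 1 to compound 2 and a 14-fold lower number (1.14 log units; beyond the scatter) from compound 3 to compound 4, 7.3-fold (0.86 log units) apart, beyond the scatter of two such steps

The size of the step on one core therefore gave no safe guide to its size on the other in this series. This does not show that the core alone sets the size: the two steps also sit at different places on the chain, and each rests on a single pair of compounds.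

On these data alone, whether hex-5-yn-1-yl on the core of compound 1 would also give a much lower number stays open, and that comparison would help separate the effect of the core from that of the chain. Also open, as far as these compounds go, is whether a longer chain than hex-5-yn-1-yl would lower the number further on the core of compound 4 or raise it again.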